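Hydrolytic half-life of a thioimidate after demethylation

The compounds below may be only part of what the source reports. "The series", "measured", "known", "first", "only" and "open" are said of these compounds alone.

Of the compounds shown here, three have been measured in a physicochemical assay for pharmacokinetics, in phosphate buffer, with a stated time of 30 min, at pH 7.4, tested at 1 mM, in the absence of a further agent; on this read-out higher numbers stand for a longer-lived compound and lower numbers for a shorter-lived compound. Compound 1 `S=C(NCc1ccccc1)c1cccs1` gives 0.0717 h. Compound 2 `COc1ccc(C(=N)SCc2ccccc2)cc1` gives 0.289 h, and compound 3 `N=C(SCc1ccccc1)c1cccs1` gives 0.449 h. Among these three numbers compound 2 stands second highest: its nearest neighbour is compound 3, whose number is higher by an amount that lies within the scatter of repeated measurements, so no order between the two can be read. Its furthest neighbour is compound 1, whose number is lower by a gap that lies beyond the scatter.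

The next compound, compound 4 `N=C(SCc1ccccc1)c1ccc(O)cc1`, has not yet been measured in this assay. It differs from compound 2 in one place: hydrogen in place of methyl on an oxygen on an aromatic ring. Among the compounds with values here, no pair of measured compounds shows this difference, so there is no measured step to lean on; only the values of compounds 1, 2 and 3 are known.

With nothing to point either way, the step from compound 2 to compound 4 is expected to be small, a 1.0-fold higher number from compound 2 to compound 4 (0.00 log units; within the scatter), and to stay within the scatter. Compound 4 is therefore estimated at 0.29 h in this assay, with a range from 0.12 h to 0.75 h.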

Compound 4, half-life: 0.088 h
Estimate against measurement, compound 4: 3.3-fold (0.52 log units) above; the whole stated range lies above it.
By their numbers in this assay, from the lowest: compounds 1 and 4 (each within the scatter of the next); then compounds 2 and 3 (each within the scatter of the next).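

Hydrogen in place of methyl on an oxygen on an aromatic ring gives, in this assay, a 3.3-fold lower number from compound 2 to compound 4 (0.52 log units; beyond the scatter). Within the data shown here, this is the first pair that differs in one place, and it shows that the position is not silent: removing a single methyl, with the rest of the structure unchanged, moves the half-life beyond the scatter and toward a shorter-lived compound, which the earlier compounds, with no such pair among them, could not show. The data shown offer no measured property that would account for this step.

As far as these compounds go, it remains open whether the shorter half-life belongs to the free hydroxy specifically or whether other replacements at this place, such as an amine, a carboxylic acid or a longer chain like ethoxy on the same oxygen, would leave the half-life near that of compound 2 or move it as well. Among these compounds, it is also open whether the same change from methoxy to hydroxy would produce a step of similar size on a different core, since this single pair is the only evidence for it.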